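Swapping an aryl substituent on the shared core

This account rests on a few compounds, and the source may have more. Where it says the series, first, only, none or still open, it means among the compounds named here.

Measured compounds:
Compound 1, `COc1ccc(-c2ccc3c(NCCCNCc4cc(F)ccc4OC)ccnc3c2)cc1`, gives 5960 nM.
Compound 2, `COc1ccc(F)cc1CNCCCNc1ccnc2cc(Cc3cccc(C(F)(F)F)c3)ccc12`, gives 440 nM.
Compound 3, `FC(F)(F)c1cccc(Cc2ccc3c(NCCCNCc4ccco4)ccnc3c2)c1`, gives 3190 nM.

These three compounds were characterised in an ADME assay on HepG2 cells (Homo sapiens) for cytotoxicity, read by luminescence, CellTiter-Glo and ATP content, with a stated time of 72 h; a lower number here means that less compound is needed, a higher number that more compound is needed for the effect. Compound 2 stands at the lowest of the three numbers; its nearest neighbour is compound 3, reached by a 7.3-fold higher number from compound 2 to compound 3 (0.86 log units; beyond the scatter), and its furthest is compound 1, which is separated from it by a 14-fold lower number from compound 1 to compound 2 (1.13 log units; beyond the scatter).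

Compound 4, `COc1ccc(F)cc1CNCCCNc1ccnc2cc(-c3ccccc3)ccc12`, has not yet been measured. It differs from compound 2 at one place: phenyl in place of 3-(trifluoromethyl)benzyl on an aromatic carbon.

Among the compounds with values here, the step that bears on this change is the one from compound 1 to compound 2, a 14-fold lower number from compound 1 to compound 2 (1.13 log units; beyond the scatter), where the same 3-(trifluoromethyl)benzyl group entered in place of an aryl group directly attached to the aromatic carbon. Compound 4 reverses that kind of change, returning to a directly attached phenyl. The step from compound 2 to compound 3, a 7.3-fold higher number from compound 2 to compound 3 (0.86 log units; beyond the scatter), touches a different position and bears less directly on it. A step upward, of a size somewhat smaller than the step from compound 1 to compound 2, is therefore expected, an 8.0-fold higher number from compound 2 to compound 4 (0.90 log units; beyond the scatter). Compound 4 is estimated at 3500 nM, with a range from 1500 nM to 8000 nM.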

Compound 4, half-maximal effective concentration: 2960 nM
The estimate for compound 4 lay 1.2-fold (0.07 log units) above the measured number; the measured number falls inside the stated range.
By their numbers in this assay, from the lowest: compound 2; then compounds 4, 3 and 1 (each within the scatter of the next).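

In this assay, the phenyl for 3-(trifluoromethyl)benzyl exchange on the aromatic carbon gives a 6.7-fold higher number from compound 2 to compound 4 (0.83 log units; beyond the scatter), which isolates the effect of this group in a single change, with the rest of compound 2 kept. The added comparison of directly attached aryl groups, hydrogen in place of methoxy, gives a 2.0-fold lower number from compound 1 to compound 4 (0.30 log units; within the scatter), so the methoxy makes no difference that can be told from the scatter, and among these three compounds the low number stays with the 3-(trifluoromethyl)benzyl group. No measurement offered here accounts for this difference.

The compounds shown leave open whether the step belongs to the trifluoromethyl group or to the carbon linking the two rings. An unsubstituted benzyl group and a 3-(trifluoromethyl)phenyl group would tell these apart.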